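The compounds below may be only part of what the source reports. "The series", "measured", "known", "first", "only" and "open" are said of these compounds alone.

Measured so far:
Compound 1, `c1ccc(-c2ccc(Cn3cncc3CNc3cccc(-c4ccccc4)c3)cc2)cc1`, in a toxicity assay on NIH3T3 cells (Mus musculus) for cytotoxicity, read by resazurin assay (a lower number here means that less compound is needed, a higher number that more compound is needed for the effect), compound 1 gives 10000 nM.
Compound 2, `CCOC(=O)c1ccc(NCc2cncn2Cc2ccc(-c3ccccc3)cc2)cc1-c1ccccc1`, in this assay compound 2 gives only a limit of the assay, > 10000 nM.
Compound 3, `COC(=O)c1ccc(NCc2cncn2Cc2cccc(OC)c2)cc1-c1ccccc1`, has no result in this assay; for compound 3 the entry reads "not determined" (no result reported).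

Compound 2 therefore stands at the upper edge of what this assay reports, with no single number. Compound 4, `c1ccc(-c2ccc(Cn3cncc3CNc3ccc(-c4cc5ccccc5o4)c(-c4ccccc4)c3)cc2)cc1`, differs from it as follows: 1-benzofuran-2-yl in place of ethoxycarbonyl on an aromatic carbon. Among the compounds with values here, the only measured step that touches compound 2 is a number no lower from compound 1 to compound 2 (the limit leaves the size open); its size stays open, since compound 2 sits at the limit (the limit of > 10000 nM in this assay, at which 1 of the 3 values shown sits). Within the data shown here, no measured step covers a 1-benzofuran-2-yl group. The step of a number no higher from compound 2 to compound 4 (the limit leaves the size open) is thus expected to be small or unreadable, with a fair chance that compound 4 again gives only a limit. Compound 4 is estimated at 10000 nM, within 3000 nM to 30000 nM.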

Compound 4, half-maximal effective concentration: > 10000 nM
Compound 4: only a limit was reported (the forecaster's own chance of this, stated with the estimate: 55%); the middle value lies on the limit itself.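

In this assay compound 4 gives > 10000 nM, a limit of the assay and not a number. Putting 1-benzofuran-2-yl in place of hydrogen at this position gives a number no lower from compound 1 to compound 4 (the limit leaves the size open), so a ring group now joins ethoxycarbonyl in giving no single number, and the step between these two limits cannot be read. Such limits now recur in this small set: the limit of > 10000 nM in this assay, at which 2 of the 4 values shown sit.

Which of the two groups needs more compound for the effect stays open. So does whether an amine or a carboxylic acid at this position would give a value that can be read.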